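From 3-chlorophenyl to 4-fluorophenyl in compound 3

The source may hold more compounds than are shown below. What is called first, only, known or untested is meant among the compounds shown, and "the series" means these compounds.

Compound 1 `CCCN1CCN(c2ccc(S(=O)(=O)Oc3ccccc3CC)cc2)C1=O`: 2300 nM
Compound 2 `CCCN1CCN(c2ccc(S(=O)(=O)Oc3cccc(Cl)c3)cc2)C1=O`: 380 nM

In a functional assay on MCF7 cells (Homo sapiens) for antiproliferative activity, read by sulforhodamine B assay, with a stated time of 48 h (a lower number here means a stronger inhibitor, a higher number a weaker inhibitor), compound 2 holds the lower of the two numbers, with the other measured compound well above it. The next compound, compound 3 `CCCN1CCN(c2ccc(S(=O)(=O)Oc3ccc(F)cc3)cc2)C1=O`, keeps the shared core and differs in one place: 4-fluorophenyl in place of 3-chlorophenyl on an oxygen. Here, 4-fluorophenyl stands in place of 3-chlorophenyl on an oxygen. Within the data shown here, only one measured step bears on this, a 6.1-fold lower number from compound 1 to compound 2 (0.78 log units; beyond the scatter). It exchanged the group on that same oxygen and shows that this group can move the number, but it does not involve 4-fluorophenyl, so the evidence is indirect. Among the measured compounds shown here, compound 2, at 380 nM, is the lowest value so far, so a small move towards a higher number is expected. The estimated step is a 1.7-fold higher number from compound 2 to compound 3 (0.23 log units; within the scatter). For compound 3 the expected value is 650 nM, with an estimated range of 200 nM to 2200 nM.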

Compound 3, half-maximal inhibitory concentration: 33000 nM
Estimate against measurement, compound 3: 51-fold (1.71 log units) below, and the stated range ends below it.
By their numbers in this assay, from the lowest: compound 2; then compound 1; then compound 3.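

At the oxygen whose other neighbour is the sulfonyl sulfur, the phenyl group can move the number much further than the first pair showed: in this assay there is an 87-fold higher number from compound 2 to compound 3 (1.94 log units; beyond the scatter). This happens although 3-chlorophenyl and 4-fluorophenyl match in heavy atom count, ring, hydrogen-bond donors, hydrogen-bond acceptors and charge, so these counted features do not separate the two groups. The new compound also falls past the earlier weaker one, with a 14-fold higher number from compound 1 to compound 3 (1.16 log units; beyond the scatter), and nothing given here explains the loss.

The halogen and its place on the ring change together in this step, so the compounds shown cannot say which of the two matters. A 3-fluorophenyl or 4-chlorophenyl group on the same oxygen would separate them, while unsubstituted phenyl would show what either halogen contributes.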